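Notes on compound 4 as a variant of compound 2

This account rests on a few compounds, and the source may have more. Where it says the series, first, only, none or still open, it means among the compounds named here.

Three compounds have been run in an assay on isolated protein for inhibition of Ephrin type-B receptor 4 (Homo sapiens), read by HTRF, tested at 10 uM; a higher number here means more inhibition at the concentration tested (going by the name of the read-out), a lower number less inhibition. Compound 1 `Cc1cccc(Oc2ccnc(N3CCN(C(=O)c4c(C)noc4C)CC3)n2)c1` gives 0%. Compound 2 `Cc1cccc(Oc2ccnc(N3CCC[C@H]3C(=O)NCCCn3ccnc3)n2)c1` gives 0%, and compound 3 `Clc1ccc2sc(CN3CCN(c4ncnc5c4CN(Cc4ccccc4)CC5)CC3)cc2c1` gives 0%. Compound 2 is thus level with compounds 1 and 3 within the scatter, and no ordering among the three can be read from these numbers. Compound 4 `Cc1cccc(Oc2ccnc(N3CCC[C@H]3C(=O)NCc3cccnc3)n2)c1` has not been measured in this assay. It differs from compound 2 in one place: pyridin-3-yl in place of 2-(1H-imidazol-1-yl)ethyl on a saturated chain carbon bound to an amide-type nitrogen. Cut one bond further out, the same difference reads 3-(1H-imidazol-1-yl)propyl to (pyridin-3-yl)methyl. Among the measured compounds shown here, no step between measured compounds is available to calibrate this change, and the three values give nothing to build on. The expected step of no change at the digits printed from compound 2 to compound 4 (within the scatter) is none beyond the scatter. Compound 4 is estimated at 0%, with a range from -5% to 10%.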

Compound 4, a percentage reported as inhibition, at one concentration (the size of the read-out at that concentration, not a potency): 0%
Estimate against measurement, compound 4: no gap at the digits printed; the measured number falls inside the stated range.
By their numbers in this assay, from the lowest: compounds 1, 2, 3 and 4 (each within the scatter of the next).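

Among the compounds shown here, replacing 3-(1H-imidazol-1-yl)propyl with (pyridin-3-yl)methyl on the amide-type nitrogen gives no change at the digits printed from compound 2 to compound 4 (within the scatter) in this assay and provides the first step between measured compounds. Exchanging one aromatic ring and its chain for the other therefore does not separate the pair at this position. No measured evidence bears on this result. As far as these compounds go, whether a carboxylic acid or a primary amine in place of (pyridin-3-yl)methyl would read differently remains open. With all four compounds level, nothing yet shows which part of the structure governs this read-out.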